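Heteroaryl swap on the alkyne of the shared core

A few compounds are considered here, and "the series" means these few. Any claim that something is new, unique, unknown or untested is made for them only; others in the source may bear on it.

For the measured compounds named here, compound 2 `CCc1ccc(C#Cc2nc(NC)c3ncn([C@H]4[C@H](O)[C@H](O)[C@]5(C(=O)NC)C[C@H]45)c3n2)o1` gives the lower of the two numbers so far: in an assay on CHO cells for displacement of a labelled ligand from adenosine receptor A3 (Homo sapiens), read by scintillation counting, with a stated time of 60 min (a lower number here means a stronger inhibitor, a higher number a weaker inhibitor), compound 2 gives 1.5 nM. Compound 1 `CNC(=O)[C@@]12C[C@@H]1[C@@H](n1cnc3c(NC)nc(C#Cc4cnn(C)c4)nc31)[C@H](O)[C@@H]2O` in this assay gives 2.34 nM, and the step of a 1.6-fold lower number from compound 1 to compound 2 (0.19 log units; within the scatter) leaves the two compounds within the scatter of each other. Compound 3 `CNC(=O)[C@@]12C[C@@H]1[C@@H](n1cnc3c(NC)nc(C#Cc4ccsc4)nc31)[C@H](O)[C@@H]2O` is not yet measured; it differs from compound 2 by thiophen-3-yl in place of 5-ethylfuran-2-yl on a triple-bonded carbon. Going by the values given here, the only measured step bearing on this change is the exchange of one five-membered aromatic ring with one hetero atom for another on the same triple-bonded carbon, and that step, a 1.6-fold lower number from compound 1 to compound 2 (0.19 log units; within the scatter), stayed within the scatter. On that basis the step of a 2.0-fold higher number from compound 2 to compound 3 (0.30 log units; within the scatter) is expected to stay within the scatter, with no clear direction. For compound 3 the estimate in this assay is 3 nM, with a range from 1 nM to 9 nM.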

Compound 3, inhibition constant: 0.52 nM
Compound 3: the middle estimate sits 5.8-fold (0.76 log units) above what was measured, and the stated range ends above it.
By their numbers in this assay, from the lowest: compound 3; then compounds 2 and 1 (each within the scatter of the next).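

At the triple-bonded carbon, the identity of the five-membered aromatic ring does register in this assay: thiophen-3-yl gives a 2.9-fold lower number from compound 2 to compound 3 (0.46 log units; beyond the scatter) against 5-ethylfuran-2-yl and a 4.5-fold lower number from compound 1 to compound 3 (0.65 log units; beyond the scatter) against 1-methyl-1H-pyrazol-4-yl. Compound 3 therefore has the lowest number of the three, separated from both others by modest steps beyond the scatter, whereas the earlier exchange between compound 1 and compound 2 had shown no separation. No measurement at hand accounts for this result.

The step from 5-ethylfuran-2-yl to thiophen-3-yl changes the ring, its point of attachment and the ethyl group at once, so these contributions remain unseparated. Unsubstituted furan-2-yl, thiophen-2-yl and 5-ethylthiophen-2-yl would each isolate one part of this change, and a longer chain such as propyl on the thiophene remains open.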